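Replacing the (1-phenylethyl)carbamoyl group of compound 2

This account rests on a few compounds, and the source may have more. Where it says the series, first, only, none or still open, it means among the compounds named here.

compound 1 `CCCCc1oc2ccccc2c1C(=O)c1ccc(OCC(=O)N2CCCCC2)cc1`: > 50000 nM (a limit)
compound 2 `CCCCc1oc2ccccc2c1C(=O)c1ccc(OCC(=O)N[C@H](C)c2ccccc2)cc1`: 14100 nM

Among the measured compounds shown here, in a functional assay on MCF7 cells (Homo sapiens) for antiproliferative activity, read by MTT assay, with a stated time of 24 h (a higher number here means a weaker inhibitor, a lower number a stronger inhibitor), compound 2 gives 14100 nM, the only true number so far. Compound 1 is reported only as a limit, > 50000 nM.

The next compound is compound 3 `CCCCc1oc2ccccc2c1C(=O)c1ccc(OCCCC(=O)N2CCCCC2)cc1`. Its difference from compound 2 is 2-((piperidin-1-yl)carbonyl)ethyl in place of (1-phenylethyl)carbamoyl on a saturated chain carbon bound to an oxygen on an aromatic ring: 2-((piperidin-1-yl)carbonyl)ethyl stands in place of (1-phenylethyl)carbamoyl on a saturated chain carbon bound to an oxygen on an aromatic ring.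

For the measured compounds named here, one measured step bears on this, an at least 3.5-fold lower number from compound 1 to compound 2 (0.54 log units; beyond the scatter), with (1-phenylethyl)amino in place of piperidin-1-yl on a carbonyl carbon. Its size is known only as a minimum. Compound 3 gives up that (1-phenylethyl) amide and carries a piperidin-1-yl carbonyl again, so a step of similar size in the opposite direction, to a higher number in this assay, is expected. Going by the values given here, no measurement yet separates the contribution of the chain.

The expected change is a 2.8-fold higher number from compound 2 to compound 3 (0.45 log units; beyond the scatter). Compound 3 is estimated at 40000 nM, with an expected range from 15000 nM to 100000 nM.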

Compound 3, half-maximal inhibitory concentration: 33000 nM
Compound 3: middle estimate off by 1.2-fold (0.08 log units), on the high side, and the stated range covers the measured number.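

In this assay, the change at this saturated chain carbon gives a 2.3-fold higher number from compound 2 to compound 3 (0.37 log units; beyond the scatter), so the (1-phenylethyl)carbamoyl group keeps a modest edge over 2-((piperidin-1-yl)carbonyl)ethyl, and compound 3 is the only one of the piperidin-1-yl amides shown with a true number. Set against the shorter (piperidin-1-yl)carbonyl group, the 2-((piperidin-1-yl)carbonyl)ethyl group gives an at least 1.5-fold lower number from compound 1 to compound 3 (0.18 log units; that floor lies within the scatter), and since that floor lies within the scatter, the longer chain cannot yet be called an improvement. Compound 1 stands only as a limit, so this step has a floor and no true size: the limit of > 50000 nM in this assay, at which 1 of the 3 values shown sits.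

Going by these compounds, the step from compound 2 to compound 3 alters the amide group and the chain together, so the share of each remains open, and the (1-phenylethyl)amino group on the longer chain would be the direct test. Also open, on these data alone, is whether a carboxylic acid, a morpholine amide or a still longer chain at this position would move the number in either direction.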